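Removing the benzyl from the aromatic nitrogen: compound 4

A few compounds are considered here, and "the series" means these few. Any claim that something is new, unique, unknown or untested is made for them only; others in the source may bear on it.

Of the compounds shown here, three of the shared core have been measured in an assay on isolated protein for inhibition of phosphodiesterase 1 (Bos taurus); on this read-out lower numbers stand for stronger inhibition and higher numbers for weaker inhibition. Compound 1 `CN1C(=O)c2c(nn(Cc3ccccc3)c2-c2ccccc2)N2C1=N[C@@H]1CCC[C@@H]12` gives 540 nM. Compound 2 `CN1C(=O)c2cnn(Cc3ccccc3)c2N2C1=N[C@@H]1CCC[C@@H]12` gives 29000 nM, and compound 3 `Cc1nn(Cc2ccccc2)c2c1C(=O)N(C)C1=N[C@@H]3CCC[C@@H]3N12` gives 2000 nM. Among the compounds with values here, compound 3 thus stands second highest of the three numbers: the one single-change step, a 15-fold lower number from compound 2 to compound 3 (1.16 log units; beyond the scatter), is large and beyond the scatter, while against compound 1 compound 3 shows a higher number, also beyond the scatter.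

Compound 4 `Cc1n[nH]c2c1C(=O)N(C)C1=N[C@@H]3CCC[C@@H]3N12` differs from compound 3 in one place: hydrogen in place of benzyl on an aromatic nitrogen. Within the data shown here, no measured step concerns this change; the step from compound 2 to compound 3 is a methyl in place of hydrogen on an aromatic carbon, and compounds 1 and 3 differ at more than one place. Going by these compounds, every measured compound carries the benzyl, so the weight of this group is untested. Among the measured compounds shown here, with no precedent, the expectation for compound 4 is a moderate move to a higher number, a 4.0-fold higher number from compound 3 to compound 4 (0.60 log units; beyond the scatter), with wide uncertainty. Compound 4 is therefore estimated at 8000 nM in this assay, between 2000 nM and 40000 nM.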

Compound 4, half-maximal inhibitory concentration: 18000 nM
Compound 4: the middle estimate sits 2.3-fold (0.35 log units) below what was measured; measured number inside the range.
By their numbers in this assay, from the lowest: compound 1; then compound 3; then compounds 4 and 2 (each within the scatter of the next).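

In this assay, a 9.0-fold higher number from compound 3 to compound 4 (0.95 log units; beyond the scatter) gives the benzyl on the aromatic nitrogen its first measured weight, a modest step but one beyond the scatter. With the methyl in place on the aromatic carbon, the benzyl therefore contributes to inhibition, and a bare hydrogen at this nitrogen keeps only part of it. Nothing on hand accounts for this step, and whether the loss comes from the six-membered aromatic ring or from the carbon joining it to the nitrogen cannot be told.

Open, going by these compounds, is whether a shorter or longer link to the aromatic ring, as in phenyl or phenethyl, or a benzyl carrying an amine or a carboxylic acid, would improve on the benzyl. Also open, on these data alone, is whether removing the benzyl costs as much from compound 1, with its phenyl in place of the methyl.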